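A few compounds are considered here, and "the series" means these few. Any claim that something is new, unique, unknown or untested is made for them only; others in the source may bear on it.

In a functional assay on HL-60 cells (Homo sapiens) for cytotoxicity, read by WST assay, with a stated time of 48 h (on this read-out higher numbers stand for an effect only at larger amounts of compound and lower numbers for an effect already at smaller amounts), three compounds built on a shared core have been measured. Compound 1 (`O=C1OC[C@H](Cc2ccccc2)[C@H]1Cc1cccc(Cl)c1`) gives 36000 nM, compound 2 (`COc1ccc(C[C@H]2C(=O)OC[C@@H]2Cc2ccccc2)cc1`) gives 67000 nM, and compound 3 (`O=C1OC[C@H](Cc2ccccc2)[C@H]1Cc1ccc(OC(F)(F)F)cc1`) gives 27000 nM. Compound 3 stands within the scatter of compound 1, while its number lies beyond the scatter under that of compound 2.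

The next compound, compound 4 (`CCCCOc1ccc(C[C@H]2C(=O)OC[C@@H]2Cc2ccccc2)cc1`), has butyl in place of trifluoromethyl on an oxygen on an aromatic ring. The same difference reads as trifluoromethoxy to butoxy. Among the compounds with values here, one measured step bears on this place, a 2.5-fold lower number from compound 2 to compound 3 (0.39 log units; beyond the scatter), and it is modest. Within the data shown here, no measured compound carries butyl there, so the data give no firm direction for the new change. A shift of similar modest size is the most that can be expected, and none beyond the scatter is anticipated. The expected change is a 1.1-fold higher number from compound 3 to compound 4 (0.05 log units; within the scatter). The estimate for compound 4 is 30000 nM, with an expected range from 11000 nM to 75000 nM.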

Compound 4, half-maximal effective concentration: 23000 nM
Beside the measured number, compound 4's estimate is 1.3-fold (0.12 log units) above it; the range from low to high includes it.
By their numbers in this assay, from the lowest: compounds 4, 3, 1 and 2 (each within the scatter of the next, the first and the last beyond it).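

In this assay, butyl and trifluoromethyl on an oxygen on an aromatic ring cannot be told apart: the result is a 1.2-fold lower number from compound 3 to compound 4 (0.07 log units; within the scatter), even though the two groups share no atoms. The other step, a 2.9-fold lower number from compound 2 to compound 4 (0.46 log units; beyond the scatter), shows that a group without fluorine can also give a lower number at this place, so the earlier drop with trifluoromethyl was not particular to fluorine. No measurement offered here explains either step.

The compounds shown leave open whether a longer chain such as hexyl on that oxygen would lower the number further, or whether an amine or a carboxylic acid at the end of the chain would change it. Also open, going by these compounds, is how a free hydroxyl on the aromatic ring, with no chain on the oxygen, would read in this assay.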